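Swapping the amine on a shared core

The compounds below may be only part of what the source reports. "The series", "measured", "known", "first", "only" and "open" are said of these compounds alone.

Compound 1 `CCCNCC(=O)N1N=C(c2cc3ccccc3oc2=O)CC1c1ccccc1` reads 4880 nM
Compound 2 `CC(C)(C)NCC(=O)N1N=C(c2cc3ccccc3oc2=O)CC1c1ccccc1` reads 15400 nM

Both numbers come from a functional assay on MGC-803 cells (Homo sapiens) for cytotoxicity, read by MTT assay, with a stated time of 48 h (on this read-out higher numbers stand for weaker inhibition and lower numbers for stronger inhibition), and compound 2 holds the higher of the two, which makes it the weaker inhibitor of this pair. Compound 3 `CC1CCCN(CC(=O)N2N=C(c3cc4ccccc4oc3=O)CC2c2ccccc2)C1` has not been measured yet. It differs from compound 2 as follows: 3-methylpiperidin-1-yl in place of (tert-butyl)amino on a saturated chain carbon bound to a carbonyl carbon and so 3-methylpiperidin-1-yl takes the place of (tert-butyl)amino on a saturated chain carbon bound to a carbonyl carbon.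

Going by the values given here, only one measured step bears on this change, and it also replaces the tert-butyl group: a 3.2-fold higher number from compound 1 to compound 2 (0.50 log units; beyond the scatter) and that step is modest but beyond the scatter. Among the compounds with values here, a single step cannot predict a ring amine, since no compound with such a ring has been measured. Still, tert-butyl gave the higher number in that one comparison, so a modest step towards a lower number is expected in this assay here. The expected change is a 2.1-fold lower number from compound 2 to compound 3 (0.31 log units; beyond the scatter) by this estimate. Compound 3 is estimated at 7500 nM with an expected range from 2500 nM to 22000 nM as the likely span.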

Compound 3, half-maximal inhibitory concentration: "not active" (no number reported)
For compound 3 the study gives words and no number; there is nothing to compare the estimate with.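

In this assay, going by these compounds alone, compound 3 is reported only in words, as "not active", with no number, so no step from compound 2 to compound 3 can be read. The compounds shown leave open how far 3-methylpiperidin-1-yl in place of (tert-butyl)amino shifts the reading. No other data here bear on this result.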